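The source may report more compounds than this note shows. Statements on the series, on what has been measured and on what is new or still open speak of the compounds shown alone.

Measured so far:
- compound 1 `CCS(=O)(=O)n1cc2c(n1)CN([C@H]1CO[C@H](c3cc(F)ccc3F)[C@@H](N)C1)C2` gives 5.2 h
- compound 2 `CC(C)S(=O)(=O)n1cc2c(n1)CN([C@H]1CO[C@H](c3cc(F)ccc3F)[C@@H](N)C1)C2` gives 1.3 h

In an ADME assay on the whole organism for metabolic stability, with Rattus norvegicus as the target (on this read-out lower numbers stand for a shorter-lived compound and higher numbers for a longer-lived compound), compound 2 holds the lower of the two numbers, at 1.3 h. Compound 3 `N[C@H]1C[C@@H](N2Cc3cn(S(=O)(=O)C4CCCC4)nc3C2)CO[C@@H]1c1cc(F)ccc1F` has cyclopentyl in place of isopropyl on a sulfonyl sulfur. Going by the values given here, only one measured step bears on this: a 4.0-fold lower number from compound 1 to compound 2 (0.60 log units; beyond the scatter). That modest step, beyond the scatter, came with methyl in place of hydrogen on a saturated chain carbon. It is a single step, so only a small change is expected here, leaning lower and perhaps no larger than the scatter: a 1.3-fold lower number from compound 2 to compound 3 (0.11 log units; within the scatter). Compound 3 is estimated at 1 h, with an expected range from 0.4 h to 2.6 h.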

Compound 3, half-life: 1.5 h
Compound 3: the middle estimate sits 1.5-fold (0.18 log units) below what was measured; the measured number falls inside the stated range.
By their numbers in this assay, from the lowest: compounds 2 and 3 (each within the scatter of the next); then compound 1.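

In this assay, cyclopentyl in place of isopropyl on a sulfonyl sulfur gives a 1.2-fold higher number from compound 2 to compound 3 (0.06 log units; within the scatter), so this larger ring leaves the half-life where compound 2 had it. Cyclopentyl in place of ethyl gives a 3.5-fold lower number from compound 1 to compound 3 (0.54 log units; beyond the scatter), which shows that the shorter half-life seen with isopropyl is not unique to isopropyl but recurs with cyclopentyl, while ethyl in compound 1 stands apart. Nothing available explains this shared result. As far as these compounds go, it remains open whether methyl, cyclopropyl or a dimethylamino group on the sulfonyl sulfur would match compound 1.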